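Working notes: replacing the 2-methoxyphenyl of compound 1

The compounds below may be only part of what the source reports. "The series", "measured", "known", "first", "only" and "open" are said of these compounds alone.

Measured compounds:
compound 1 `COc1ccccc1/C=C/C(=O)OC/C=C/c1cc(OC)c(OC)cc1OC`: 50%
compound 2 `COc1cc(OC)c(OC)cc1/C=C/COC(=O)/C=C/c1ccc(Br)cc1`: 25%
compound 3 `COc1cc(OC)c(OC)cc1/C=C/COC(=O)/C=C/c1cccc(Br)c1`: 25%

The read-out is a functional assay on the whole organism (strain Kunming) with Mus musculus as the target, with a stated time of 0.5 h, at a dose of 300 mg/kg by the intraperitoneal route; a higher number here means a weaker effect of the compound at the dose given, a lower number a stronger effect. Compound 1 holds the highest number of the three; its nearest neighbour is compound 2, a number 25 percentage points lower from compound 1 to compound 2 (beyond the scatter), and compound 3 sits at the same distance, a number 25 percentage points lower from compound 1 to compound 3 (beyond the scatter). Between the two bromophenyl compounds there is no change at the digits printed from compound 2 to compound 3 (within the scatter).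

Compound 4 `COc1cc(OC)c(OC)cc1/C=C/COC(=O)/C=C/c1ccc(F)cc1` differs from compound 1 as follows: 4-fluorophenyl in place of 2-methoxyphenyl on a double-bonded chain carbon bound to a double-bonded chain carbon. Both steps that put a bromophenyl in place of the 2-methoxyphenyl, a number 25 percentage points lower from compound 1 to compound 2 (beyond the scatter) and a number 25 percentage points lower from compound 1 to compound 3 (beyond the scatter), lowered the number by the same amount, and the two bromophenyl isomers did not differ. A fall of similar size is therefore expected for compound 4, a number 20 percentage points lower from compound 1 to compound 4 (beyond the scatter). Compound 4 is estimated at 30%, with a range from 15% to 50%.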

Compound 4, a percentage reported as activity, at one dose (the size of the read-out at that dose, not a potency): 0%
Estimate against measurement, compound 4: 30 percentage points above; measured number outside the range, below it.
By their numbers in this assay, from the lowest: compound 4; then compounds 2 and 3 (each within the scatter of the next); then compound 1.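

In this assay the halogen matters at this position: fluoro in place of bromo on an aromatic carbon gives a number 25 percentage points lower from compound 2 to compound 4 (beyond the scatter), although the two bromophenyl isomers showed no difference. 4-Fluorophenyl in place of 3-bromophenyl gives a number 25 percentage points lower from compound 3 to compound 4 (beyond the scatter), and in place of 2-methoxyphenyl it gives a number 50 percentage points lower from compound 1 to compound 4 (beyond the scatter), so replacing the 2-methoxyphenyl does not give one shared fall. Nothing available explains the difference between fluoro and bromo. The compounds shown leave open whether 3-fluorophenyl would match 4-fluorophenyl and where 4-chlorophenyl would fall.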